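Tolerance of Three Analogues and a Fourth Under Study

The source may hold more compounds than are shown below. What is called first, only, known or untested is meant among the compounds shown, and "the series" means these compounds.

Compound 1 `CCC1=C(C(=O)OCC2CCCCC2)C(c2cccc(O)c2)NC(=O)N1` — > 10000 nM
Compound 2 `CC(C)C1=C(C(=O)OCC2CCCCC2)C(c2cccc(O)c2)NC(=O)N1` — "not determined" (no result reported)
Compound 3 `O=C1NC(c2ccccc2)=C(C(=O)OCC2CCCCC2)C(c2cccc(O)c2)N1` — > 10000 nM

In an ADME assay on CEMx174 cells (Homo sapiens) for cytotoxicity (a higher number here means that more compound is tolerated, a lower number that less compound is tolerated), compound 1 gives only a limit, > 10000 nM; no single number stands for it. Compound 3 likewise gives only a limit in this assay, > 10000 nM. For compound 2 this assay reports "not determined" (no result reported), so it adds nothing to the picture. For the measured compounds named here, compound 1 therefore stands among values that are all limits or absent, and the one step that joins it to another measured compound, a step that the two limits leave unreadable from compound 1 to compound 3, cannot be read in size or direction because of the limit of > 10000 nM in this assay, at which 2 of the 3 values shown sit.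

Compound 4 `CCC1=C(C(=O)OCC2CCCCC2)C(c2ccc(C(=O)O)cc2)NC(=O)N1` differs from compound 1 by 4-carboxyphenyl in place of 3-hydroxyphenyl on a saturated ring carbon. Going by the values given here, no measured step bears readably on this change, and the only evidence in this assay is that two of three values rest at the same limit. On that basis compound 4 is expected to sit at the same limit, with an estimate of 15000 nM, between 5000 nM and 50000 nM. The step that the limit leaves unreadable from compound 1 to compound 4 is thus expected to be none beyond the scatter, though the limit at compound 1 leaves its true size open.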

Compound 4, half-maximal cytotoxic concentration: > 10000 nM
Compound 4 gave a limit, no number (the forecaster's own chance of this, stated with the estimate: 80%); the middle value lies beyond the limit too.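

In this assay compound 4 gives > 10000 nM, which is a limit and not a number, so the step from compound 1 to it cannot be read in size or direction: the limit of > 10000 nM in this assay, at which 3 of the 4 values shown sit.

The compounds shown leave open whether 4-carboxyphenyl and 3-hydroxyphenyl differ at all in how much compound the cells tolerate.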